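The source may hold more compounds than are shown below. What is called first, only, known or untested is meant among the compounds shown, and "the series" means these compounds.

Compound 1 `Cc1c(O)ccc2c1[C@H](Cn1cc(-c3ccc(F)cc3)nn1)[C@@]13CC(=O)[C@@](C)(CC[C@@H]21)C3` — in a functional assay on MCF7 cells (Homo sapiens) for cytotoxicity, read by MTT assay, with a stated time of 4 days (on this read-out higher numbers stand for weaker inhibition and lower numbers for stronger inhibition), compound 1 gives > 20000 nM
Compound 2 `Cc1c(O)ccc2c1[C@H](Cn1cc(-c3ccc(C(F)(F)F)cc3)nn1)[C@@]13CC(=O)[C@@](C)(CC[C@@H]21)C3` — in this assay compound 2 gives > 20000 nM

The value for compound 1 is a limit of the assay, not a measured number. The value for compound 2 is likewise a limit. Compound 2 differs from compound 1 by a trifluoromethyl in place of fluoro on an aromatic carbon, and the step from compound 1 to compound 2 is a step that the two limits leave unreadable from compound 1 to compound 2. Both results sit at the limit of > 20000 nM in this assay, at which 2 of the 2 values shown sit, so compound 1 stands at the limit and cannot be ranked more closely against the other number shown.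

Compound 3 has the structure `Cc1ccc(S(=O)(=O)Oc2ccc3c(c2C)[C@H](Cn2cc(-c4ccc(F)cc4)nn2)[C@@]24CC(=O)[C@@](C)(CC[C@@H]32)C4)cc1`. It differs from compound 1 by (4-methylphenyl)sulfonyl in place of hydrogen on an oxygen on an aromatic ring. Going by the values given here, the only measured step, a step that the two limits leave unreadable from compound 1 to compound 2, concerns a different part of the molecule and its size cannot be read, so it gives no guide to how large the change here might be or in which direction. With compound 1 already at the limit, the expectation is that compound 3 also shows no readable inhibition in this assay, an expected step that the limit leaves unreadable from compound 1 to compound 3. Compound 3 is therefore estimated at 30000 nM, within 8000 nM to 100000 nM.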

Compound 3, half-maximal inhibitory concentration: > 20000 nM
Compound 3: only a limit was reported; the forecaster's own chance of this, stated with the estimate: 75%; the middle value does not contradict the limit.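

In this assay compound 3 gives > 20000 nM, which is a limit of the assay and not a number. Compound 1 also stands at a limit, so the step between compound 1 and compound 3 cannot be read: the limit of > 20000 nM in this assay, at which 3 of the 3 values shown sit.

How strongly any of these compounds acts on the cells, and whether swapping hydroxy for ((4-methylphenyl)sulfonyl)oxy changes that, stays open.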